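The source may report more compounds than this note shows. Statements on the series, on what has been measured and on what is new or still open speak of the compounds shown alone.

Measured so far:
- compound 1, `CCN(C(=O)COc1ccc(C)cc1)C(C)c1cccs1`: "not active" (no number reported)
- compound 2, `CCN(Cc1cccs1)C(=O)C(C)Oc1ccc(C)cc1`: 889 nM
- compound 3, `Cc1ccc(OCC(=O)N(Cc2cccs2)c2nccs2)cc1`: 2240 nM

In an assay on HEK293 cells for agonist activity at transient receptor potential cation channel subfamily M member 8 (Homo sapiens), read by fluorescence and calcium flux, with a stated time of 15 min (a lower number here means that less compound is needed, a higher number that more compound is needed for the effect), compound 1 is reported as "not active" (no number reported), so no number stands against it. Compound 2 gives 889 nM in this assay, and compound 3 gives 2240 nM; those two numbers are the only ones available, and they say nothing about the size of any step from compound 1, since compound 1 has no number.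

Compound 4, `CCN(Cc1ccc(C)s1)C(=O)COc1ccc(C)cc1`, is the unmeasured compound. It keeps every atom of compound 1 but joins them differently: (5-methylthiophen-2-yl)methyl in place of 1-(thiophen-2-yl)ethyl on an amide-type nitrogen

Among the measured compounds shown here, no pair of measured compounds differs in this one place alone, so the size of the step has to be guessed rather than read off. The expectation is that compound 4 will show a real effect in this assay where compound 1 showed none, which would be a step well beyond the scatter in the direction of activity, because compound 2 gives 889 nM and compound 3 gives 2240 nM with related arrangements of the same pieces; that reason is weak. For compound 4 the estimated value in this assay is 1500 nM, expected to lie between 400 nM and 6000 nM.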

Compound 4, half-maximal effective concentration: 178 nM
Compound 4: middle estimate off by 8.4-fold (0.93 log units), on the high side; measured number outside the range, below it.
By their numbers in this assay, from the lowest: compound 4; then compound 2; then compound 3.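

Among the compounds shown here, compound 1 is reported as "not active" (no number reported) and compound 4 gives 178 nM, so no step with a size can be read between compound 1 and compound 4. No supporting evidence bears on this result. The compounds shown leave open how much of the activity of compound 4 depends on (5-methylthiophen-2-yl)methyl itself.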